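The compounds below may be only part of what the source reports. "The series", "measured", "known", "first", "only" and "open" are said of these compounds alone.

Compound 3 `OCc1ccc(-c2nn(Cc3ccccc3)c3ccccc23)cc1` carries a hydroxymethyl group on the shared core. In a functional assay on cells (Platelet, Homo sapiens) for inhibition (on this read-out higher numbers stand for weaker inhibition and lower numbers for stronger inhibition), compound 3 gives > 10000 nM, which is a limit of the assay and not a number. Two related compounds are known: compound 1 `CNC(=O)c1ccc(-c2nn(Cc3ccccc3)c3ccccc23)cc1` and compound 2 `CCCNC(=O)c1ccc(-c2nn(Cc3ccccc3)c3ccccc23)cc1`. In this assay compound 1 gives > 10000 nM, again a limit. In this assay compound 2 gives > 10000 nM, also a limit. Because all three values sit at the limit of > 10000 nM in this assay, at which 3 of the 3 values shown sit, the steps a step that the two limits leave unreadable from compound 1 to compound 2, a step that the two limits leave unreadable from compound 1 to compound 3 and a step that the two limits leave unreadable from compound 2 to compound 3 cannot be read. Compound 4 `CCOC(=O)/C=C/c1ccc(-c2nn(Cc3ccccc3)c3ccccc23)cc1` differs from compound 3 by 2-(ethoxycarbonyl)ethenyl in place of hydroxymethyl on an aromatic carbon. Within the data shown here, no measured step offers a readable size, so the step that the limit leaves unreadable from compound 3 to compound 4 is expected to stay close to nothing. Compound 4 is estimated at 12000 nM, within 3000 nM to 40000 nM, most likely once more only a limit.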

Compound 4, half-maximal inhibitory concentration: > 10000 nM
Compound 4 gave a limit, no number (the forecaster's own chance of this, stated with the estimate: 75%); the middle value is on the limit's open side.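

The value of compound 4 is a limit, so its steps from compound 1, compound 2 and compound 3 cannot be read, and all the values sit at one limit: the limit of > 10000 nM in this assay, at which 4 of the 4 values shown sit.

Which group on the shared core, if any, would give a readable number in this assay stays open.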